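Methyl substituent on the shared core of compound 3

The compounds below may be only part of what the source reports. "The series", "measured", "known", "first", "only" and "open" are said of these compounds alone.

Among the measured compounds shown here, compound 3 `O=C([C@H]1Cc2cc(Cl)cc(-c3ccnc4cc(C(O)(CO)CCl)sc34)c2O1)N1CCNCC1` carries the lowest number of the three measured members: in an assay on isolated protein for inhibition of ubiquitin carboxyl-terminal hydrolase 7 (Homo sapiens), read by fluorescence, with stated times of 30 min and 1 h (on this read-out lower numbers stand for stronger inhibition and higher numbers for weaker inhibition), compound 3 gives 9 nM. Compound 2 `O=C([C@H]1Cc2cc(Cl)cc(-c3ccnc4cc(Cn5cnccc5=O)sc34)c2O1)N1CCNCC1` gives 27 nM, and the unsubstituted parent compound 1 `O=C([C@H]1Cc2cc(Cl)cc(-c3ccnc4ccsc34)c2O1)N1CCNCC1` gives 90 nM. The steps run a 3.3-fold lower number from compound 1 to compound 2 (0.52 log units; beyond the scatter), a 10-fold lower number from compound 1 to compound 3 (1.00 log units; beyond the scatter) and a 3.0-fold lower number from compound 2 to compound 3 (0.48 log units; beyond the scatter), so each group added on the aromatic carbon of the core has brought a modest gain over hydrogen.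

Compound 4 `Cc1cc2nccc(-c3cc(Cl)cc4c3O[C@@H](C(=O)N3CCNCC3)C4)c2s1` differs from compound 3 by methyl in place of 1-(chloromethyl)-1,2-dihydroxyethyl on an aromatic carbon, on an aromatic carbon of a five-membered aromatic ring with 1 sulfur, part of a fused or bridged system of two rings, next to the ring sulfur. The bearing steps are those from hydrogen to the two larger groups; methyl is smaller than either and carries none of their donors or acceptors, so compound 4 is expected to sit between compound 1 and compound 3. The expected step is a 5.6-fold higher number from compound 3 to compound 4 (0.74 log units; beyond the scatter), a higher number. Compound 4 is estimated at 50 nM, with a range from 20 nM to 130 nM.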

Compound 4, half-maximal inhibitory concentration: 130 nM
The estimate for compound 4 lay 2.6-fold (0.41 log units) below the measured number, within the range that was stated.
By their numbers in this assay, from the lowest: compound 3; then compound 2; then compounds 1 and 4 (each within the scatter of the next).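

Methyl on this aromatic carbon, next to the ring sulfur, is not distinguishable from hydrogen in this assay: a 1.4-fold higher number from compound 1 to compound 4 (0.16 log units; within the scatter). Among the compounds shown here, a gain at this position therefore does not come with any small carbon substituent, but is seen only with the larger groups, as a 14-fold higher number from compound 3 to compound 4 (1.16 log units; beyond the scatter) and a 4.8-fold higher number from compound 2 to compound 4 (0.68 log units; beyond the scatter) show. No available measurement bears on what lies behind this difference.

The compounds shown change the whole 1-(chloromethyl)-1,2-dihydroxyethyl group at once, so it remains open which part of it carries the gain. Also open, going by these compounds, is how a hydroxymethyl, an aminomethyl or a carboxylic acid on this carbon would compare with compound 3 .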